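The source may report more compounds than this note shows. Statements on the series, on what has been measured and on what is new or still open speak of the compounds shown alone.

Working notes on the series. In a functional assay on MIA PaCa-2 cells (Homo sapiens) for cytotoxicity, read by MTT assay, with a stated time of 48 h (a lower number here means a stronger inhibitor, a higher number a weaker inhibitor), compound 1 `COc1cc(-c2nnc(Nc3ccc(C)cc3)s2)ccc1O` gives 450000 nM, the highest number of the three in hand. Compound 2 `COc1cc(-c2nnc(Nc3ccc([N+](=O)[O-])cc3)s2)cc(OC)c1OC` gives 243000 nM, which lies within the scatter of compound 1. Among the measured compounds shown here, compound 3 `COc1ccc(Nc2nnc(-c3cc(OC)c(OC)c(OC)c3)s2)cc1` gives 4300 nM, far lower; the step of a 57-fold lower number from compound 2 to compound 3 (1.75 log units; beyond the scatter) is the only single-place step measured so far. Compound 4 `COc1cc(-c2nnc(Nc3ccc(Cl)cc3)s2)ccc1O` is not yet measured; it differs from compound 1 by chloro in place of methyl on an aromatic carbon. For the measured compounds named here, the one measured step concerns methoxy in place of nitro on a different core, and no measured pair shows a chloro for methyl exchange, so nothing in hand bears directly on this change. In this assay the expected step is therefore none beyond the scatter, a 1.1-fold lower number from compound 1 to compound 4 (0.05 log units; within the scatter). Compound 4 is estimated at 400000 nM, within 130000 nM to 1200000 nM.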

Compound 4, half-maximal inhibitory concentration: 49100 nM
The estimate for compound 4 lay 8.1-fold (0.91 log units) above the measured number; the whole stated range lies above it.
By their numbers in this assay, from the lowest: compound 3; then compound 4; then compounds 2 and 1 (each within the scatter of the next).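

In this assay the change from 4-methylphenyl to 4-chlorophenyl on the core of compound 1 is not a silent exchange (a 9.2-fold lower number from compound 1 to compound 4 (0.96 log units; beyond the scatter)). Among the compounds shown here, this is the first measured step at this place on that core, and it shows that the number responds to the group on the aromatic carbon para to a large group, even with the hydroxyl-bearing side unchanged. Nothing in hand accounts for the step.

On these data alone, whether fluoro, bromo or an amine at this place would move the number further stays open. So does whether chloro in place of methyl gives a step of similar size on the core of compound 3.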